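A few compounds are considered here, and "the series" means these few. Any claim that something is new, unique, unknown or untested is made for them only; others in the source may bear on it.

In a functional assay on cells (Homo sapiens) for antiproliferative activity, read by MTT assay, with a stated time of 48 h (on this read-out higher numbers stand for weaker inhibition and lower numbers for stronger inhibition), compound 1 `Cn1c(N)c(-c2nc3ccccc3[nH]2)c2nc(C#N)c(C#N)nc21` reads > 50000 nM, which is a limit of the assay and not a number. Going by the values given here, compound 2 `CN(C)CCCCn1c(-c2c(N)n(C)c3nc(C#N)c(C#N)nc23)nc2ccccc21`, bearing a 4-(dimethylamino)butyl group on an aromatic nitrogen, gives 6480 nM, the only true number so far in this assay. Among the compounds with values here, the one measured step, an at least 7.7-fold lower number from compound 1 to compound 2 (0.88 log units; beyond the scatter), is the sole evidence available, and it concerns the appearance of the whole chain. Within the data shown here, no measured step varies the amine at the end of that chain. Compound 3 `CCN(CC)CCCCn1c(-c2c(N)n(C)c3nc(C#N)c(C#N)nc23)nc2ccccc21` keeps the chain and the shared core of compound 2 and makes a single change: diethylamino in place of dimethylamino on a saturated chain carbon, four bonds along the chain from an aromatic nitrogen. In words, diethylamino stands in place of dimethylamino on a saturated chain carbon, four bonds along the chain from an aromatic nitrogen. As the chain itself is retained, the gain seen in an at least 7.7-fold lower number from compound 1 to compound 2 (0.88 log units; beyond the scatter) is expected to persist, and no step beyond the scatter is expected in this assay. The expected change is a 1.2-fold lower number from compound 2 to compound 3 (0.07 log units; within the scatter). Compound 3 is estimated at 5500 nM, with an expected range from 2200 nM to 14000 nM.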

Compound 3, half-maximal inhibitory concentration: 6950 nM
Compound 3: middle estimate off by 1.3-fold (0.10 log units), on the low side; measured number inside the range.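

In this assay, diethylamino in place of dimethylamino on a saturated chain carbon, four bonds along the chain from an aromatic nitrogen, gives a 1.1-fold higher number from compound 2 to compound 3 (0.03 log units; within the scatter), so the two amines cannot be told apart on this read-out. The gain from adding the chain now appears with a second amine and not with one alone, as the chain ending in diethylamino gives an at least 7.1-fold lower number from compound 1 to compound 3 (0.85 log units; beyond the scatter). Compound 1 stands at a limit of the assay and not at a number, so the full size of that gain remains unknown: the limit of > 50000 nM in this assay, at which 1 of the 3 values shown sits.

On these data alone, whether a ring amine such as pyrrolidine or morpholine at the end of the chain, a carboxylic acid in place of the amine, or a shorter chain such as 3-(diethylamino)propyl would move the number beyond the scatter remains open. Equally open, as far as these compounds go, is how much of the gain belongs to the amine and how much to the chain itself, a question that a plain butyl group on that aromatic nitrogen would address.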